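Placing Chloro at a Different Spot: Expected Cytotoxicity

The compounds below may be only part of what the source reports. "The series", "measured", "known", "first", "only" and "open" are said of these compounds alone.

Measured compounds and their values:
- Compound 1 `O=C1CSC(c2ccccc2Cl)N1c1nnc(S)s1`: 200000 nM
- Compound 2 `O=C1CSC(c2ccccc2)N1c1nnc(S)s1`: > 423000 nM
- Compound 3 `NS(=O)(=O)c1ccc(NC(=O)CSc2nnc(N3C(=O)CSC3c3ccccc3Cl)s2)cc1`: >= 18800 nM

In an ADME assay on MT4 cells (Homo sapiens) for cytotoxicity, read by MTT assay, with a stated time of 5 days (on this read-out higher numbers stand for lower toxicity in this test and lower numbers for higher toxicity in this test), compound 1 gives 200000 nM. Compound 2 reaches only a limit of the assay, > 423000 nM, so no exact number is known for it. Compound 3, which carries a much larger group on its shared core, also stops at a limit, >= 18800 nM. Compound 2 thus stands at the least toxic end among the numbers shown, but only as a limit, which the limit of > 423000 nM in this assay, at which 1 of the 3 values shown sits, records.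

Compound 4 `O=C1CSC(c2cccc(Cl)c2)N1c1nnc(S)s1` differs from compound 2 by chloro in place of hydrogen on an aromatic carbon. Going by the values given here, the one measured step that bears on this change is an at least 2.1-fold higher number from compound 1 to compound 2 (0.32 log units; beyond the scatter), where removing a chloro group from the same ring raised the number at least modestly. Adding chloro back, now at another place, is therefore expected to lower the number by a modest amount, an at least 1.6-fold lower number from compound 2 to compound 4 (0.22 log units; that floor lies within the scatter), though the limit for compound 2 leaves the size uncertain. Compound 4 is estimated at 250000 nM, with a range from 100000 nM to 600000 nM.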

Compound 4, half-maximal cytotoxic concentration: 238000 nM
Compound 4: middle estimate off by 1.1-fold (0.02 log units), on the high side; low and high end bracket the measured number.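

The change from hydrogen to chloro at this position, meta to a large group, comes with an at least 1.7-fold lower number from compound 2 to compound 4 (0.24 log units; that floor lies within the scatter). In this assay compound 1, with chloro at another place on the same ring, gives 200000 nM and compound 4 gives 238000 nM, two values within the usual scatter of each other, so moving the chloro shows no readable difference. The true size of the step from hydrogen to chloro stays unknown because compound 2 stands at a limit of the assay, not at an exact number: the limit of > 423000 nM in this assay, at which 1 of the 4 values shown sits.

Still open, on these data alone, is whether another group at this position, such as an amine, a carboxylic acid or a methoxy group, would change the number at all. Also open is how compound 3 compares with the smaller compounds, because compound 3 too stands at a limit of the assay: the limit of >= 18800 nM in this assay, at which 1 of the 4 values shown sits.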